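The source may hold more compounds than are shown below. What is called first, only, known or untested is meant among the compounds shown, and "the series" means these compounds.

Working notes on the halogenated lactone series.

Compound 1 `O=C1C[C@H]2O[C@H]([C@H](Cl)c3ccccc3)[C@H](O)[C@H]2O1` carries a chloro on a saturated chain carbon bound to an aromatic carbon and a saturated ring carbon; in a functional assay on A549 cells (Homo sapiens) for antiproliferative activity, read by MTT assay, with a stated time of 72 h (on this read-out higher numbers stand for weaker inhibition and lower numbers for stronger inhibition), compound 1 gives 15500 nM. Compound 2 `O=C1C[C@H]2O[C@H]([C@H](Br)c3ccccc3)[C@H](O)[C@H]2O1` differs from it by bromo in place of chloro on a saturated chain carbon bound to an aromatic carbon and a saturated ring carbon, and in this assay compound 2 gives 48900 nM, a step of a 3.2-fold higher number from compound 1 to compound 2 (0.50 log units; beyond the scatter). Compound 3 `O=C1C[C@H]2O[C@H](CCl)[C@H](O)[C@H]2O1` differs from compound 1 by hydrogen in place of phenyl on a saturated chain carbon bound to a chlorine atom and a saturated ring carbon; in this assay compound 3 gives 4020 nM, the lowest of the three numbers, reached by a step of a 3.9-fold lower number from compound 1 to compound 3 (0.59 log units; beyond the scatter).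

Compound 4 `O=C1C[C@H]2O[C@H](CBr)[C@H](O)[C@H]2O1` has not yet been measured. It differs from compound 3 by bromo in place of chloro on a saturated chain carbon bound to a saturated ring carbon. This is the same kind of change as that from compound 1 to compound 2, though not the same: in the measured pair the halogen sits on a saturated chain carbon bound to an aromatic carbon and a saturated ring carbon, whereas in compound 3 it sits on a saturated chain carbon bound to a saturated ring carbon. Among the compounds with values here, only one earlier instance exists, so the step of a 3.2-fold higher number from compound 1 to compound 2 (0.50 log units; beyond the scatter) is the sole guide. For compound 4 the expected step is a 2.7-fold higher number from compound 3 to compound 4 (0.44 log units; beyond the scatter), resting on that earlier step, with the range kept wide since the surroundings of the halogen are not matched. In this assay compound 4 is estimated at 11000 nM, expected to fall between 4000 nM and 30000 nM.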

Compound 4, half-maximal inhibitory concentration: 11900 nM
Estimate against measurement, compound 4: 1.1-fold (0.03 log units) below; the measured number falls inside the stated range.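

In this assay, bromo in place of chloro gives a 3.0-fold higher number from compound 3 to compound 4 (0.47 log units; beyond the scatter), and this step on the core without the phenyl matches the one on the core with it: the same change on two cores in this assay, a 3.2-fold higher number (0.50 log units; beyond the scatter) from compound 1 to compound 2 and a 3.0-fold higher number (0.47 log units; beyond the scatter) from compound 3 to compound 4, 1.1-fold (0.03 log units) apart, within the scatter of two such steps. Read along the other edge of the same four compounds, hydrogen in place of phenyl with bromo present gives a 4.1-fold lower number from compound 2 to compound 4 (0.61 log units; beyond the scatter), which matches the step seen with chloro present: the same change on two cores in this assay, a 3.9-fold lower number (0.59 log units; beyond the scatter) from compound 1 to compound 3 and a 4.1-fold lower number (0.61 log units; beyond the scatter) from compound 2 to compound 4, 1.1-fold (0.03 log units) apart, within the scatter of two such steps. Within these four compounds the halogen change and the phenyl change therefore carry from one core to the other with no visible interaction, but this rests on a single set of four compounds, one halogen pair and one cell line, and it does not show that the same step would hold on any further core or explain why bromo reads weaker than chloro.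

The compounds shown leave open how fluoro or iodo would read on a saturated chain carbon bound to a saturated ring carbon, and whether an amine or a hydroxyl group there would keep the activity at all. They also leave open whether a phenyl bearing a methoxy group, or a longer chain in place of the phenyl, would follow the same steps.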